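A few compounds are considered here, and "the series" means these few. Any claim that something is new, unique, unknown or untested is made for them only; others in the source may bear on it.

Of the compounds shown here, two that share one core have so far been measured in a functional assay on UACC-257 cells (Homo sapiens) for antiproliferative activity, with a stated time of 48 h; a higher number here means a weaker inhibitor of growth, a lower number a stronger inhibitor of growth. Compound 1 `Cc1cc(O)c(C2=NN(c3ccc(S(N)(=O)=O)cc3)C(/C=C/c3ccccc3)C2)cc1Cl` gives 14500 nM. Compound 2 `COc1ccc(C2CC(c3cc(Cl)c(C)cc3O)=NN2c2ccc(S(N)(=O)=O)cc2)cc1OC` gives 4220 nM. Among the compounds with values here, the single step between them, a 3.4-fold lower number from compound 1 to compound 2 (0.54 log units; beyond the scatter), is the only guide available, and of the two numbers compound 2 holds the lowest. Compound 3 `COc1ccc(C2CC(c3cc(Cl)c(C)cc3O)=NN2c2ccc(S(N)(=O)=O)cc2)c(OC)c1OC` differs from compound 2 by methoxy in place of hydrogen on an aromatic carbon; the new group sits on an aromatic carbon of a six-membered aromatic ring of carbon only, ortho to a large group, ortho to a methoxy group and meta to a methoxy group. Within the data shown here, no measured step bears on a change of this kind: the one step known swaps the whole group on the saturated ring carbon rather than adding to it. In this assay the step of a 1.1-fold lower number from compound 2 to compound 3 (0.02 log units; within the scatter) is therefore expected to stay within the scatter. Compound 3 is estimated at 4000 nM, with a range from 1500 nM to 11000 nM.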

Compound 3, concentration for 50% growth inhibition: 4130 nM
Compound 3: the middle estimate sits 1.0-fold (0.01 log units) below what was measured; the range from low to high includes it.
By their numbers in this assay, from the lowest: compounds 3 and 2 (each within the scatter of the next); then compound 1.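

Placing a methoxy group on this aromatic carbon, ortho to a large group, ortho to a methoxy group and meta to a methoxy group, turns 3,4-dimethoxyphenyl into 2,3,4-trimethoxyphenyl, and in this assay this gives a 1.0-fold lower number from compound 2 to compound 3 (0.01 log units; within the scatter). The number therefore does not tell the two groups apart, and the 2,3,4-trimethoxyphenyl group also gives a 3.5-fold lower number from compound 1 to compound 3 (0.55 log units; beyond the scatter), a step of about the same size as the one seen earlier for 3,4-dimethoxyphenyl. Nothing measured here offers a reason for this result.

The compounds shown leave open whether an ethoxy group, an amine or a carboxylic acid on this same aromatic carbon would also stay within the scatter of compound 2. From the compounds shown here alone, it also remains open whether removing either of the other two methoxy groups would matter as little.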